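Replacing Fluoro with Methoxy in Compound 2

This account rests on a few compounds, and the source may have more. Where it says the series, first, only, none or still open, it means among the compounds named here.

Compound 1 `O=C(CSc1nnc(-c2ccncc2)o1)c1ccccc1` gives 370 nM
Compound 2 `O=C(CSc1nnc(-c2ccccc2F)o1)c1ccccc1` gives 260 nM
Compound 3 `Nc1cc(-c2nnc(SCC(=O)c3ccccc3)o2)ccn1` gives 140 nM

These values come from a functional assay on MCF7 cells (Homo sapiens) for cytotoxicity, read by MTT assay and propidium iodide staining, with a stated time of 24 h (a higher number here means a weaker inhibitor, a lower number a stronger inhibitor), and compound 2 lies within the scatter of both other compounds, with a 1.4-fold lower number from compound 1 to compound 2 (0.15 log units; within the scatter) and a 1.9-fold lower number from compound 2 to compound 3 (0.27 log units; within the scatter) as its two steps. Compound 4 `COc1ccccc1-c1nnc(SCC(=O)c2ccccc2)o1` differs from compound 2 by methoxy in place of fluoro on an aromatic carbon, ortho to a large group. Among the measured compounds shown here, no measured step makes this exact change. Only a 2.6-fold lower number from compound 1 to compound 3 (0.42 log units; beyond the scatter) goes beyond the scatter, and it is modest. No step beyond the scatter is therefore expected in this assay here. The expected step is a 1.0-fold lower number from compound 2 to compound 4 (0.02 log units; within the scatter) and it stays within the scatter. Compound 4 is expected at 250 nM with 110 nM to 550 nM as the estimated range.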

Compound 4, half-maximal inhibitory concentration: 2070 nM
For compound 4 the middle estimate is 8.3-fold (0.92 log units) below the measured one; measured number outside the range, above it.
By their numbers in this assay, from the lowest: compounds 3, 2 and 1 (each within the scatter of the next, the first and the last beyond it); then compound 4.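

In this assay, methoxy in place of fluoro on an aromatic carbon ortho to a large group gives an 8.0-fold higher number from compound 2 to compound 4 (0.90 log units; beyond the scatter) and shows that this place is sensitive to the group it carries. The earlier compounds shown here did not show this, since none of them changes only the group on this six-membered aromatic ring of carbon only, and their largest step is smaller than this one. Nothing available gives a reason for this step.

From the compounds shown here alone, whether a methyl, a hydroxy or a chloro group at this place would stay with compound 2 or move with compound 4 remains open. Also open, going by these compounds, is whether methoxy on the other carbons of this ring would give a step of similar size.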